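Amino in place of dimethylamino on a methylsulfanyl-bearing core

This account rests on a few compounds, and the source may have more. Where it says the series, first, only, none or still open, it means among the compounds named here.

Compound 1 `CN(C)c1nc(Br)nc2c1ncn2[C@@H]1C[C@@H](O)[C@H](CO)O1` carries a dimethylamino group and a bromo group. In a functional assay on K562 cells (Homo sapiens) (a lower number here means a stronger inhibitor, a higher number a weaker inhibitor), compound 1 gives only a limit, > 300 uM. Compound 2 `Nc1nc(Br)nc2c1ncn2[C@@H]1C[C@@H](O)[C@H](CO)O1` differs by amino in place of dimethylamino on an aromatic carbon, and in this assay compound 2 gives 83 uM, so that an at least 3.6-fold lower number from compound 1 to compound 2 (0.55 log units; beyond the scatter). Compound 3 `CSc1nc(N(C)C)c2ncn([C@@H]3C[C@@H](O)[C@H](CO)O3)c2n1` differs from compound 1 by methylsulfanyl in place of bromo on an aromatic carbon. In this assay compound 3 likewise gives a limit, > 300 uM. Hence a step that the two limits leave unreadable from compound 1 to compound 3. The ceiling of the measurement is the limit of > 300 uM in this assay, at which 2 of the 3 values shown sit. Compound 4 `CSc1nc(N)c2ncn([C@@H]3C[C@@H](O)[C@H](CO)O3)c2n1` has not been measured; it differs from compound 3 by amino in place of dimethylamino on an aromatic carbon, the same kind of change as from compound 1 to compound 2, though here meta to a methylsulfanyl group rather than meta to a bromo group. Because an at least 3.6-fold lower number from compound 1 to compound 2 (0.55 log units; beyond the scatter), compound 4 is expected to show an at least 2.0-fold lower number from compound 3 to compound 4 (0.30 log units; that floor lies within the scatter). In this assay compound 4 is estimated at 150 uM, between 40 uM and 400 uM.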

Compound 4, concentration for 50% inhibition: > 300 uM
Compound 4: a limit, no number; the forecaster's own chance of this, stated with the estimate: 40%; middle value at least 2.0-fold (0.30 log units) away from the limit.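

In this assay compound 4 gives > 300 uM, which is a limit and not a number. Among the compounds shown here, the steps that end at such limits cannot be read, so the change from dimethylamino to amino is neither confirmed nor ruled out on the methylsulfanyl-bearing core, where compound 3 and compound 4 both stand at the ceiling: the limit of > 300 uM in this assay, at which 3 of the 4 values shown sit. The only readable new step is an at least 3.6-fold higher number from compound 2 to compound 4 (0.55 log units; beyond the scatter), for methylsulfanyl in place of bromo, and it shows only that the bromo-bearing compound 2 keeps a measurable value in this pair.

On these data alone, it remains open whether an ethylsulfanyl, methoxy or chloro group in place of methylsulfanyl would give a measurable value. A methylamino group in place of amino is equally untested among the compounds shown.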